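Removing a Methoxy Group: From Compound 3 to Compound 4

A few compounds are considered here, and "the series" means these few. Any claim that something is new, unique, unknown or untested is made for them only; others in the source may bear on it.

Compound 1, `N#C/C(=C\c1c(-c2ccccc2)[nH]c2ccccc12)C(=O)c1ccccc1`: "not determined" (no result reported)
Compound 2, `COc1ccc(-c2[nH]c3ccccc3c2/C=C(\C#N)S(=O)(=O)c2ccccc2)cc1`: 344 nM
Compound 3, `COc1ccc2[nH]c(-c3ccccc3)c(/C=C(\C#N)S(=O)(=O)c3ccccc3)c2c1`: 3100 nM

In a functional assay on SK-MEL-5 cells (Homo sapiens) for inhibition, read by sulforhodamine B assay, with a stated time of 48 h (a lower number here means a stronger inhibitor of growth, a higher number a weaker inhibitor of growth), compound 1 has no reported number. Among the two numbers that exist, compound 3 gives the highest, 3100 nM. Compound 2 gives 344 nM, a gap from compound 3 that lies beyond the usual scatter. Compound 4, `N#C/C(=C\c1c(-c2ccccc2)[nH]c2ccccc12)S(=O)(=O)c1ccccc1`, differs from compound 3 by hydrogen in place of methoxy on an aromatic carbon. No measured pair shows this change on its own, so the expectation rests on the numbers shown. A step toward a lower number, beyond the scatter, is expected in this assay, partly because compound 2 gives 344 nM with no methoxy on that ring. The expected step is a 3.4-fold lower number from compound 3 to compound 4 (0.54 log units; beyond the scatter). Compound 4 is estimated at 900 nM, with a range from 250 nM to 3000 nM.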

Compound 4, concentration for 50% growth inhibition: 1820 nM
For compound 4 the middle estimate is 2.0-fold (0.31 log units) below the measured one; the measured number falls inside the stated range.
By their numbers in this assay, from the lowest: compound 2; then compounds 4 and 3 (each within the scatter of the next).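

In this assay, replacing the methoxy that stands meta to a fused ring and para to a fused ring with hydrogen gives a 1.7-fold lower number from compound 3 to compound 4 (0.23 log units; within the scatter), a step within the scatter, so this position shows no readable difference between the two groups. The same replacement at the other methoxy place gives a 5.3-fold higher number from compound 2 to compound 4 (0.72 log units; beyond the scatter), which lies beyond the scatter, so among these compounds the size of the step depends on where the change is made. Nothing given here accounts for either step. From the compounds shown here alone, whether an amine or a carboxylic acid on that aromatic carbon would shift the number beyond the scatter remains open.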